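Moving the Hydroxyl on the Aryl Ring of Compound 3

The source may hold more compounds than are shown below. What is called first, only, known or untested is meant among the compounds shown, and "the series" means these compounds.

Compound 3 `CN1CCN(c2nc(-c3cccc(O)c3)nc3[nH]cnc23)CC1` was tested in an assay on cells for displacement of a labelled ligand from adenosine receptor A3 (Homo sapiens), read by scintillation counting and radioligand binding, with a stated time of 180 min, tested at 10 uM; a higher number here means more inhibition at the concentration tested (going by the name of the read-out), a lower number less inhibition. Its value there, > 80%, is a limit of the assay rather than a number. Compound 2 `CN1CCN(c2nc(-c3ccc(Cl)c(Cl)c3)nc3[nH]cnc23)CC1` likewise reaches only a limit, > 80%. Compound 1 `CN1CCN(c2nc(-c3cccc(O)c3)nc3c2ncn3C)CC1` gives 63.8% in this assay, and the step of a number at least 16.2 percentage points higher from compound 1 to compound 3 (beyond the scatter) accompanies hydrogen in place of methyl on an aromatic nitrogen. The step that the two limits leave unreadable from compound 2 to compound 3, which alters the aryl group, cannot be sized because of the limit of > 80% in this assay, at which 2 of the 3 values shown sit. Compound 4 `CN1CCN(c2nc(-c3ccc(O)cc3)nc3[nH]cnc23)CC1` differs from compound 3 by 4-hydroxyphenyl in place of 3-hydroxyphenyl on an aromatic carbon. For the measured compounds named here, no measured step moves a hydroxyl; the one aryl change seen leaves both compounds at the limit, so the step of a number at least 2 percentage points lower from compound 3 to compound 4 (that floor lies within the scatter) is expected to lie within the scatter. Compound 4 is therefore estimated at 78%, between 60% and 90%.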

Compound 4, a percentage reported as inhibition, at one concentration (the size of the read-out at that concentration, not a potency): 48%
Compound 4: the middle estimate sits 30 percentage points above what was measured, and the stated range ends above it.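

In this assay, the position of the hydroxyl on the aryl ring proves to matter: the two groups have the same atoms, joined differently, yet 4-hydroxyphenyl in place of 3-hydroxyphenyl gives a number at least 32 percentage points lower from compound 3 to compound 4 (beyond the scatter). Taking 4-hydroxyphenyl in place of 3,4-dichlorophenyl gives a number at least 32 percentage points lower from compound 2 to compound 4 (beyond the scatter), so this aromatic carbon is sensitive to the aryl group it carries. The step between the other two aryl groups still cannot be read: the limit of > 80% in this assay, at which 2 of the 4 values shown sit.

The compounds shown leave open how a methoxyphenyl or an aminophenyl group would read at this carbon. They also leave open whether the 4-hydroxyphenyl change would give a similar step with methyl on the aromatic nitrogen, as in compound 1.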